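Solubility notes: methoxy to trifluoromethyl on compound 3

This account rests on a few compounds, and the source may have more. Where it says the series, first, only, none or still open, it means among the compounds named here.

Compound 3 `COc1ccc(-c2ccc3c(NCCCNCc4ccco4)ccnc3c2)cc1` gives 32000 nM in a physicochemical assay for solubility, with a stated time of 18 h, at pH 7.4 (a lower number here means a less soluble compound, a higher number a more soluble compound), the highest of the three numbers in hand. Compound 1 `c1ccc(Oc2ccc3c(NCCCNCc4ccco4)ccnc3c2)cc1` gives 14500 nM and compound 2 `Fc1ccc(Oc2ccc3c(NCCCNCc4ccco4)ccnc3c2)cc1` gives 14500 nM in this assay. The steps of a 2.2-fold higher number from compound 1 to compound 3 (0.34 log units; beyond the scatter) and a 2.2-fold higher number from compound 2 to compound 3 (0.34 log units; beyond the scatter) are modest, while the step of no change at the digits printed from compound 1 to compound 2 (within the scatter) is flat. Compound 4 `FC(F)(F)c1ccc(-c2ccc3c(NCCCNCc4ccco4)ccnc3c2)cc1` differs from compound 3 by trifluoromethyl in place of methoxy on an aromatic carbon. Going by the values given here, no measured step covers this exchange: the only step that brings fluorine in is no change at the digits printed from compound 1 to compound 2 (within the scatter), and no measured pair removes a methoxy. The expected step in this assay is a modest lowering, a 2.1-fold lower number from compound 3 to compound 4 (0.33 log units; beyond the scatter), with little confidence in its direction. Compound 4 is estimated at 15000 nM, expected to lie between 5000 nM and 40000 nM.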

Compound 4, solubility: 32000 nM
Beside the measured number, compound 4's estimate is 2.1-fold (0.33 log units) below it; the range from low to high includes it.
By their numbers in this assay, from the lowest: compounds 1 and 2 (each within the scatter of the next); then compounds 3 and 4 (each within the scatter of the next).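

In this assay the exchange of methoxy for trifluoromethyl para to a large group reads no change at the digits printed from compound 3 to compound 4 (within the scatter) so this position accepts either group with no separable difference. Both a 2.2-fold higher number from compound 1 to compound 4 (0.34 log units; beyond the scatter) and a 2.2-fold higher number from compound 2 to compound 4 (0.34 log units; beyond the scatter) match the steps to compound 3, so the higher number is no longer tied to the 4-methoxyphenyl group alone and also holds for 4-(trifluoromethyl)phenyl. Nothing in hand bears on why the exchange is flat.

As far as these compounds go, whether an amine or a carboxylic acid at this position would shift the number away from that of compound 3 and compound 4 stays open.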